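This account rests on a few compounds, and the source may have more. Where it says the series, first, only, none or still open, it means among the compounds named here.

Working notes on the series. Three compounds have a number in an assay on isolated protein for inhibition of retinal dehydrogenase 2 (Homo sapiens); a higher number here means a weaker inhibitor, a lower number a stronger inhibitor. Compound 1 `Cn1ncc2c(=O)n(-c3ccccc3)c(/C=C/c3cccc(F)c3)nc21` gives 440 nM. Compound 2 `COc1cccc(C(C)Sc2nc3c(cnn3C)c(=O)n2-c2ccccc2)c1` gives 108 nM in this assay. Compound 3 `C#Cc1ccc(-n2c(SC(C)c3ccccc3)nc3c(cnn3C)c2=O)cc1` gives 800 nM in this assay, the highest of the three numbers; compound 1 lies within the scatter of it, so the two are not separated, while compound 2 lies beyond the scatter with its lower number. Among the compounds with values here, no pair among the three differs in one place only, so no single step is isolated by these data.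

Compound 4 `CC(Sc1nc2c(cnn2C)c(=O)n1-c1ccc(CCO)cc1)c1ccccc1` is not yet measured in this assay. It is derived from compound 3 by one change: 2-hydroxyethyl in place of ethynyl on an aromatic carbon. The change sits on an aromatic carbon of a six-membered aromatic ring of carbon only, para to a large group, and the ethynyl gives way to a 2-hydroxyethyl that brings one hydrogen-bond donor and one hydrogen-bond acceptor. Nothing in the measured set tests this position, so the expectation rests on the general picture alone.

The step of a 1.3-fold lower number from compound 3 to compound 4 (0.12 log units; within the scatter) is expected to be small, most likely none beyond the scatter, with a slight lean toward a lower number. Compound 4 is therefore estimated at 600 nM in this assay, with a range from 200 nM to 1800 nM.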

Compound 4, half-maximal inhibitory concentration: 216 nM
For compound 4 the middle estimate is 2.8-fold (0.44 log units) above the measured one; the range from low to high includes it.
By their numbers in this assay, from the lowest: compounds 2 and 4 (each within the scatter of the next); then compounds 1 and 3 (each within the scatter of the next).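

In this assay, within the data shown here, the aromatic carbon para to a large group turns out to matter: 2-hydroxyethyl in place of ethynyl gives a 3.7-fold lower number from compound 3 to compound 4 (0.57 log units; beyond the scatter) and is the first single change isolated. The step is modest but beyond the scatter, so the number responds to what stands at this place, and a group with one hydrogen-bond donor and one hydrogen-bond acceptor is accompanied by the lower number here. Nothing at hand accounts for the step, so its size and direction are known while its origin is not.

This one step cannot separate the gain of the hydroxyl from the loss of the triple bond, and a plain ethyl group, a longer chain such as 3-hydroxypropyl, an amine or a carboxylic acid at this place would help to tell these apart. On these data alone, whether the same change gives a similar step alongside the other groups on the shared core, such as those of compound 1 and compound 2, also remains open.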